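This account rests on a few compounds, and the source may have more. Where it says the series, first, only, none or still open, it means among the compounds named here.

Measured so far:
compound 1 `COc1cc(OCc2cccc(-c3ccc(OC)nc3)c2)c2cc(-c3cn4nc(OC)sc4n3)oc2c1`: 0.733 h
compound 2 `COc1cc(OCc2cccc(-c3cnc(OC)cn3)c2)c2cc(-c3cn4nc(OC)sc4n3)oc2c1`: 1.48 h

In an ADME assay on microsomes from liver (Homo sapiens) for metabolic stability (a lower number here means that the compound disappears faster, a higher number that the compound lasts longer), compound 2 stands highest of the two numbers, and compound 1 gives 0.733 h. Going by the values given here, the one step between them, a 2.0-fold higher number from compound 1 to compound 2 (0.31 log units; beyond the scatter), came from the group change 5-methoxypyrazin-2-yl in place of 6-methoxypyridin-3-yl on an aromatic carbon.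

Compound 3 `COc1ccc(-c2cccc(COc3cc(OC)cc4oc(-c5cn6nc(OC)sc6n5)cc34)c2)nc1` is not yet measured in this assay. It differs from compound 2 in one place: 5-methoxypyridin-2-yl in place of 5-methoxypyrazin-2-yl on an aromatic carbon. This step bears on the earlier one only loosely, since the incoming 5-methoxypyridin-2-yl is not the same pyridinyl group that compound 1 carries, but the direction is the reverse: a ring with one hetero atom returns in place of one with two. A modest downward step is therefore expected, roughly undoing the gain seen from compound 1 to compound 2, with wide uncertainty. Compound 3 is estimated at 0.95 h, between 0.55 h and 1.7 h, meaning an expected step of a 1.6-fold lower number from compound 2 to compound 3 (0.19 log units; within the scatter).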

Compound 3, half-life: 0.767 h
Estimate against measurement, compound 3: 1.2-fold (0.09 log units) above, and the stated range covers the measured number.
By their numbers in this assay, from the lowest: compounds 1, 3 and 2 (each within the scatter of the next, the first and the last beyond it).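

In this assay, 5-methoxypyridin-2-yl in place of 6-methoxypyridin-3-yl gives a 1.0-fold higher number from compound 1 to compound 3 (0.02 log units; within the scatter), so these two pyridinyl groups cannot be told apart at this position on the ring of carbon only. 5-methoxypyridin-2-yl in place of 5-methoxypyrazin-2-yl gives a 1.9-fold lower number from compound 2 to compound 3 (0.29 log units; within the scatter), so the pyrazinyl group of compound 2 stands clear of compound 1 but not of compound 3, and the second ring nitrogen cannot be credited with a firm gain. Nothing available explains these numbers.

Still open, from the compounds shown here alone, is whether the small difference between the pyrazinyl and pyridinyl groups would hold up in repeat measurements. Going by these compounds, all three groups are methoxy-substituted aromatic rings, so how an amine such as morpholine, a nitrile or a longer alkoxy chain would fare at this position also remains unknown.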